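This account rests on a few compounds, and the source may have more. Where it says the series, first, only, none or still open, it means among the compounds named here.

Of the compounds shown here, two of the shared core have been measured so far, and neither gives a number. Compound 1 `COS(=O)(=O)c1ccc(F)c2ncc(I)cc12` in an assay for inhibition of methylcytosine dioxygenase TET2 (Homo sapiens), read by mass spectrometry, with stated times of 30 min and 1 h (a higher number here means a weaker inhibitor, a lower number a stronger inhibitor), gives > 200000 nM, which is a limit of the assay and not a measured value. Compound 2 `O=S(=O)(c1ccc(F)c2ncc(I)cc12)N1CCCC1` in this assay gives > 200000 nM, again a limit. The step that the two limits leave unreadable from compound 1 to compound 2 therefore cannot be sized, since both ends rest at the limit of > 200000 nM in this assay, at which 2 of the 2 values shown sit. Compound 2 thus stands at the limit and nowhere else on the numbers shown.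

Compound 3 `O=S(=O)(NC1CCCCC1)c1ccc(F)c2ncc(I)cc12` differs from compound 2 in one place: cyclohexylamino in place of pyrrolidin-1-yl on a sulfonyl sulfur. Going by the values given here, the only measured step that touches the sulfonyl sulfur, from compound 1 to compound 2, is unreadable, so there is no measured step on which to found a direction or size for the change to compound 3. With both known values at the limit, the expectation for compound 3 is that this assay will once more report only a limit, and the expected step is a step that the limit leaves unreadable from compound 2 to compound 3. For compound 3 in this assay the estimate is 300000 nM, within a range from 150000 nM to 1000000 nM.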

Compound 3, half-maximal inhibitory concentration: > 200000 nM
Compound 3: a limit, no number (the forecaster's own chance of this, stated with the estimate: 85%); the middle value lies beyond the limit too.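

In this assay compound 3 gives > 200000 nM, which is a limit of the assay and not a number. The steps to compound 3 from compound 1 and from compound 2 cannot be read, because all three compounds rest at the same limit: the limit of > 200000 nM in this assay, at which 3 of the 3 values shown sit.

The compounds shown leave open whether any group on the sulfonyl sulfur gives a measurable value in this assay.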